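A nitrophenyl amide follows the furan amide

The source may hold more compounds than are shown below. What is called first, only, known or untested is meant among the compounds shown, and "the series" means these compounds.

Compound 3 `CC(C)=CCC1Cc2c(OCCCNC(=O)c3ccco3)cc(=O)n(CCCO)c2CC1(C)C` stands lowest of the three measured compounds in a functional assay on PANC-1 cells (Homo sapiens) for inhibition, read by MTT assay, with a stated time of 24 h, tested at 10 uM (a higher number here means more inhibition at the concentration tested (going by the name of the read-out), a lower number less inhibition), giving 2.1%. Compound 1 `CC(C)=CCC1Cc2c(OCCCNS(=O)(=O)c3ccc(Cl)cc3)cc(=O)n(CCCO)c2CC1(C)C` gives 24.7%, and compound 2 `COc1ccc(C(=O)NCCCOc2cc(=O)n(CCCO)c3c2CC(CC=C(C)C)C(C)(C)C3)cc1` gives 55.5%. The step from compound 3 to compound 4 `CC(C)=CCC1Cc2c(OCCCNC(=O)c3ccc([N+](=O)[O-])cc3)cc(=O)n(CCCO)c2CC1(C)C` changes the group on the carbonyl carbon: 4-nitrophenyl in place of furan-2-yl on a carbonyl carbon. The measured step that bears most directly on it is a number 53.4 percentage points lower from compound 2 to compound 3 (beyond the scatter), in which furan-2-yl replaced a six-membered aromatic ring of carbon only; compound 4 reverses that direction. The step of a number 22.6 percentage points lower from compound 1 to compound 3 (beyond the scatter) likewise leaves compound 3 with the lowest number. A 4-nitrophenyl carbonyl has not itself been measured. Compound 4 is therefore expected to rise by a number 32.9 percentage points higher from compound 3 to compound 4 (beyond the scatter) in this assay, with an estimate of 35%, between 10% and 60%.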

Compound 4, a percentage reported as inhibition, at one concentration (the size of the read-out at that concentration, not a potency): 49.9%
For compound 4 the middle estimate is 14.9 percentage points below the measured one; the measured number falls inside the stated range.
By their numbers in this assay, from the lowest: compound 3; then compound 1; then compounds 4 and 2 (each within the scatter of the next).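

In this assay, the group on the carbonyl carbon has a large effect: a number 47.8 percentage points higher from compound 3 to compound 4 (beyond the scatter), so an amide alone does not bring the low number of compound 3. Changing the group on the aromatic carbon gives a number 5.6 percentage points lower from compound 2 to compound 4 (within the scatter), which leaves these two amides unseparated, while a number 25.2 percentage points higher from compound 1 to compound 4 (beyond the scatter) places the nitrophenyl amide, like the methoxyphenyl amide, over the chlorophenyl sulfonyl compound. Nothing available explains these steps. Still open, from the compounds shown here alone, is whether an amine or a carboxylic acid in place of nitro on the aromatic carbon would hold the number, and whether a thiophene ring on the carbonyl carbon would behave like furan-2-yl.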